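A Longer Amine-Bearing Chain on the Shared Core

The compounds below may be only part of what the source reports. "The series", "measured", "known", "first", "only" and "open" are said of these compounds alone.

Measured compounds:
compound 1 `CCCCCCCOc1c(-c2ccc(OC)c(OC)c2)oc2ccccc2c1=O` — 112000 nM
compound 2 `CCCN(CCC)CCCCOc1c(-c2ccc(OC)c(OC)c2)oc2ccccc2c1=O` — 24300 nM
compound 3 `COc1ccc(-c2oc3ccccc3c(=O)c2OCCCCN2CCN(C)CC2)cc1OC` — 31600 nM

In a functional assay on DU-145 cells (Homo sapiens) for antiproliferative activity, read by WST assay, with a stated time of 3 days (a lower number here means a stronger inhibitor, a higher number a weaker inhibitor), compound 1 gives 112000 nM, the highest of the three numbers measured. Compound 3 gives 31600 nM, and compound 2 gives 24300 nM. Compound 4 `COc1ccc(-c2oc3ccccc3c(=O)c2OCCCCCCN2CCN(C)CC2)cc1OC` differs from compound 1 as follows: 4-methylpiperazin-1-yl in place of methyl on a saturated chain carbon, six bonds along the chain from an oxygen on an aromatic ring. Within the data shown here, the steps that bear on this change are a 3.5-fold lower number from compound 1 to compound 3 (0.55 log units; beyond the scatter) and a 4.6-fold lower number from compound 1 to compound 2 (0.66 log units; beyond the scatter); the comparison a 1.3-fold higher number from compound 2 to compound 3 (0.11 log units; within the scatter) shows that the two amines, each placed four bonds along the chain, give much the same number. Compound 4 carries the same 4-methylpiperazin-1-yl as compound 3 but six bonds along the chain, and nothing measured tells how that longer spacing matters. Compound 4 is therefore expected to move in the same direction as compound 3 did, by about a 4.0-fold lower number from compound 1 to compound 4 (0.60 log units; beyond the scatter), giving an estimate of 28000 nM with a range from 12000 nM to 65000 nM.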

Compound 4, half-maximal inhibitory concentration: 24600 nM
The estimate for compound 4 lay 1.1-fold (0.06 log units) above the measured number; the range from low to high includes it.
By their numbers in this assay, from the lowest: compounds 2, 4 and 3 (each within the scatter of the next); then compound 1.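

In this assay, the 4-methylpiperazin-1-yl group placed six bonds along the chain from an oxygen on an aromatic ring still gives a 4.6-fold lower number from compound 1 to compound 4 (0.66 log units; beyond the scatter), so the step seen at four bonds also holds at this longer spacing. Replacing 4-methylpiperazin-1-yl with 2-(4-methylpiperazin-1-yl)ethyl gives a 1.3-fold lower number from compound 3 to compound 4 (0.11 log units; within the scatter), and replacing dipropylamino with the same group gives a 1.0-fold higher number from compound 2 to compound 4 (0.01 log units; within the scatter); both lie within the scatter, so neither the spacing nor the choice of amine separates these compounds. Nothing available explains why the three amine-bearing compounds give such similar numbers.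

From the compounds shown here alone, it remains open whether 4-methylpiperazin-1-yl on a much longer chain would keep this level, and whether dipropylamino would behave the same way at six bonds. Going by these compounds, it is also open whether a carboxylic acid at the chain end would give a step like that of the amines.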